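This account rests on a few compounds, and the source may have more. Where it says the series, first, only, none or still open, it means among the compounds named here.

In an assay on adrenal medulla for inhibition of Vasopressin V2 receptor (Rattus norvegicus), read by radioligand binding (a higher number here means a weaker inhibitor, a lower number a stronger inhibitor), compound 1 `CN(C)C1CCN(C(=O)CCCOc2cc(C(=O)N3CCCCc4sccc43)ccc2NC(=O)c2ccccc2-c2ccccc2)CC1` gives 3 nM, the lowest of the two numbers shown, while compound 3 `CN(C)C1CCN(C(=O)COc2cc(C(=O)N3CCCCc4sccc43)ccc2NC(=O)c2ccccc2-c2ccccc2)CC1` sits at 4 nM in this assay, within the scatter of compound 1. Compound 2 `O=C(Nc1ccc(C(=O)N2CCCCc3sccc32)cc1O)c1ccccc1-c1ccccc1` is reported in this assay only at a limit of the assay, < 10 nM. The step that the limit leaves unreadable from compound 2 to compound 3 cannot be read because the limit of < 10 nM in this assay, at which 1 of the 3 values shown sits, hides its size. Compound 4 `O=C(Nc1ccc(C(=O)N2CCCCc3sccc32)cc1OCCCC(=O)N1CCC(N2CCCCC2)CC1)c1ccccc1-c1ccccc1` differs from compound 1 by piperidin-1-yl in place of dimethylamino on a saturated ring carbon. No measured step bears on this place; the only step shown concerns the oxygen on the aromatic ring and is itself unreadable. Since compound 1 stands at 3 nM and nothing shown points in either direction, no change beyond the scatter is expected. The expected step is a 1.3-fold higher number from compound 1 to compound 4 (0.12 log units; within the scatter). Compound 4 is accordingly estimated at 4 nM, between 1.5 nM and 12 nM.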

Compound 4, half-maximal inhibitory concentration: 20 nM
Compound 4: middle estimate off by 5.0-fold (0.70 log units), on the low side; measured number outside the range, above it.
By their numbers in this assay, from the lowest: compounds 1 and 3 (each within the scatter of the next); then compound 4.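

In this assay, piperidin-1-yl in place of dimethylamino on the saturated ring carbon gives a 6.7-fold higher number from compound 1 to compound 4 (0.82 log units; beyond the scatter) and so shows that this position responds to the group it carries, which compounds with only dimethylamino there, or without this side chain, could not show. Nothing shown accounts for the size of this step. The one earlier step, from compound 2 to compound 3, still cannot be read: the limit of < 10 nM in this assay, at which 1 of the 4 values shown sits.

From the compounds shown here alone, whether the ring or the added carbons matter remains open. Diethylamino, pyrrolidin-1-yl or morpholin-4-yl at this carbon would bear on that question.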